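Ester to anilide on the shared core: an expectation

The source may hold more compounds than are shown below. What is called first, only, known or untested is meant among the compounds shown, and "the series" means these compounds.

Compound 1 `NC(=O)c1ccc2c(c1)nc(Nc1ccc(S(N)(=O)=O)cc1)n2Cc1nc2ccccc2s1`; in an assay on isolated protein for inhibition of kinesin heavy chain isoform 5A (Homo sapiens) (on this read-out lower numbers stand for stronger inhibition and higher numbers for weaker inhibition), compound 1 gives > 50000 nM, a limit of the assay and not a number.
Compound 2 `CS(=O)(=O)c1ccc(Nc2nc3cc(C(=O)O)ccc3n2Cc2ccccc2C(F)(F)F)cc1`; compound 2 gives > 50000 nM, again only a limit.
Compound 3 `COC(=O)c1ccc2c(c1)nc(Nc1ccc(S(N)(=O)=O)cc1)n2Cc1ccccc1C(F)(F)F`; compound 3 gives > 50000 nM, also a limit.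

All three measured values sit at the limit of > 50000 nM in this assay, at which 3 of the 3 values shown sit. Compound 3 therefore stands on a limit alone, with no number that would place it against the other two. Compound 4 `COc1ccccc1NC(=O)c1ccc2c(c1)nc(Nc1ccc(S(N)(=O)=O)cc1)n2Cc1ccccc1C(F)(F)F` differs from compound 3 by (2-methoxyphenyl)amino in place of methoxy on a carbonyl carbon. Within the data shown here, no pair of measured compounds differs in a single place, so no measured step exists to guide the expectation; the three limits are the whole of the record. With every value a limit, inhibition is expected to stay weak after this change, and the step expected is a step that the limit leaves unreadable from compound 3 to compound 4, nothing beyond the scatter. Compound 4 is expected at 60000 nM, with a range from 10000 nM to 300000 nM.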

Compound 4, half-maximal inhibitory concentration: > 50000 nM
Compound 4: no number, only a limit; the forecaster's own chance of this, stated with the estimate: 75%; the middle value does not contradict the limit.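

In this assay compound 4 gives > 50000 nM, a limit and not a number. Compound 3 also stands on a limit, so no step can be read between compound 3 and compound 4. The compounds shown leave open whether any change on the shared core gives a readable value: the limit of > 50000 nM in this assay, at which 4 of the 4 values shown sit.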